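The source may report more compounds than this note shows. Statements on the series, on what has been measured and on what is new or still open speak of the compounds shown alone.

Three compounds of the series carry a measured number in a functional assay on MGC-803 cells (Homo sapiens) for cytotoxicity, read by MTT assay, with a stated time of 48 h; on this read-out higher numbers stand for weaker inhibition and lower numbers for stronger inhibition. Compound 1 `CC1=NN(C(=O)CCc2ccccc2)C(c2cc(Br)cc(Br)c2O)C1` gives 17100 nM. Compound 2 `CC1=NN(C(=O)c2ccc(C)cc2)C(c2cc(Br)cc(Br)c2O)C1` gives 56500 nM. Compound 3 `O=C(c1ccccc1Cl)N1N=C(c2cc3ccccc3oc2=O)CC1c1ccccc1` gives 6640 nM, the lowest of the three numbers; its gap to compound 1 and its gap to compound 2 both lie beyond the scatter. Among the compounds with values here, the single measured step between compounds that differ in one place is a 3.3-fold higher number from compound 1 to compound 2 (0.52 log units; beyond the scatter), the exchange of phenethyl for 4-methylphenyl on a carbonyl carbon.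

Compound 4 `CC1CCCN(CC(=O)N2N=C(c3cc4ccccc4oc3=O)CC2c2ccccc2)C1` has not yet been measured. It differs from compound 3 as follows: (3-methylpiperidin-1-yl)methyl in place of 2-chlorophenyl on a carbonyl carbon. Within the data shown here, the step from compound 1 to compound 2 is the only measured step that sits on a carbonyl carbon, and it runs from a chain to an aromatic ring, the reverse sense of the exchange here, so it bears on the present step only loosely; it does show that a change at this position can move the number beyond the scatter. Among the measured compounds shown here, no measured compound carries a six-membered non-aromatic ring with one hetero atom, so that part of the change has no precedent in the numbers. On this basis a step of a 1.7-fold lower number from compound 3 to compound 4 (0.22 log units; within the scatter) in this assay is expected, modest and toward a lower number but not secure. Compound 4 is expected to give 4000 nM in this assay, within a range from 1500 nM to 12000 nM.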

Compound 4, half-maximal inhibitory concentration: "not active" (no number reported)
Compound 4 has no reported number here, and the estimate cannot be compared.
By their numbers in this assay, from the lowest: compound 3; then compound 1; then compound 2.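

In this assay, within the data shown here, compound 4 is reported as not active, with no number, so no step from compound 3 to compound 4 can be read. The compounds shown leave open how far (3-methylpiperidin-1-yl)methyl in place of 2-chlorophenyl moves the number on this read-out. No measurement shown bears on the reason for this result.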